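Methyl on the Fused Carbocycle of the Compound 1 Core

The compounds below may be only part of what the source reports. "The series", "measured", "known", "first", "only" and "open" are said of these compounds alone.

Compound 1 `CC(C)(O)c1cncc(-n2ncc3ccccc32)c1`: 15 nM
Compound 2 `CC(C)(O)c1cncc(-n2nc(C3CC3)c3ccccc32)c1`: 760 nM
Compound 3 `Cc1ccc2c(cnn2-c2cncc(C(C)(C)O)c2)c1`: 97.9 nM

In an assay on cells for inhibition of cytochrome P450 11B2, mitochondrial (Homo sapiens), read by HTRF, with stated times of 1 h and 3 h (on this read-out lower numbers stand for stronger inhibition and higher numbers for weaker inhibition), compound 1 gives the lowest number of the three measured compounds; its steps to compound 3 and to compound 2 both lie beyond the scatter. Compound 4 `Cc1cccc2c1cnn2-c1cncc(C(C)(C)O)c1` differs from compound 1 by methyl in place of hydrogen on an aromatic carbon. Among the compounds with values here, two measured steps bear on substitution of the shared core: a 6.5-fold higher number from compound 1 to compound 3 (0.81 log units; beyond the scatter) and a 51-fold higher number from compound 1 to compound 2 (1.70 log units; beyond the scatter). Both point the same way, a weaker result on adding a carbon substituent, the smaller group giving the smaller loss. For compound 4 a modest rise in the number is therefore expected, roughly a 5.0-fold higher number from compound 1 to compound 4 (0.70 log units; beyond the scatter). The estimate for compound 4 in this assay is 75 nM, within a range of 20 nM to 300 nM.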

Compound 4, half-maximal inhibitory concentration: 7.77 nM
For compound 4 the middle estimate is 9.7-fold (0.98 log units) above the measured one; measured number below the stated range.
By their numbers in this assay, from the lowest: compounds 4 and 1 (each within the scatter of the next); then compound 3; then compound 2.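

In this assay, methyl in place of hydrogen on an aromatic carbon of the six-membered aromatic ring of carbon only gives a 1.9-fold lower number from compound 1 to compound 4 (0.29 log units; within the scatter) and so shows no loss at this position. Compound 3 gives 97.9 nM and compound 4 gives 7.77 nM with methyl at different carbons of that ring, so the earlier loss on adding methyl does not hold across the ring. No measurement shown explains this result. On these data alone, whether ethyl, methoxy or an amine at this carbon would match methyl remains open.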